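Thiophene to pyridine at the carbonyl: compound 4 outlook

A few compounds are considered here, and "the series" means these few. Any claim that something is new, unique, unknown or untested is made for them only; others in the source may bear on it.

Compound 1 `CCCN(CCC)c1cc(NC(=O)c2cccs2)cc(C(F)(F)F)c1`: in an assay on HEK293-TREx cells for antagonist activity at transient receptor potential cation channel subfamily A member 1 (Homo sapiens), read by calcium flux (on this read-out higher numbers stand for weaker inhibition and lower numbers for stronger inhibition), compound 1 gives > 32000 nM, which is a limit of the assay and not a number.
Compound 2 `CC(C)C(C)Nc1cc(NC(=O)c2cccs2)cc(C(F)(F)F)c1`: compound 2 gives 1300 nM.
Compound 3 `CCCNc1cc(NC(=O)c2cccs2)cc(C(F)(F)F)c1`: compound 3 gives 390 nM.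

Compound 3 holds the lowest number of the two measured, with compound 2 next, the step being a 3.3-fold lower number from compound 2 to compound 3 (0.52 log units; beyond the scatter). The shared core is kept in compound 4 `CCCNc1cc(NC(=O)c2ccncc2)cc(C(F)(F)F)c1`, changed only at the carbonyl: pyridin-4-yl in place of thiophen-2-yl on a carbonyl carbon. Every measured step, including an at least 24-fold lower number from compound 1 to compound 2 (1.39 log units; beyond the scatter) and an at least 82-fold lower number from compound 1 to compound 3 (1.91 log units; beyond the scatter), concerns the nitrogen on the aromatic ring, so none bears on the carbonyl substituent. No direction is therefore supported; the step of a 2.6-fold higher number from compound 3 to compound 4 (0.41 log units; beyond the scatter) is set as an expectation with a wide range. Compound 4 is estimated at 1000 nM, between 200 nM and 6000 nM.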

Compound 4, half-maximal inhibitory concentration: 2600 nM
For compound 4 the middle estimate is 2.6-fold (0.41 log units) below the measured one; measured number inside the range.
By their numbers in this assay, from the lowest: compound 3; then compounds 2 and 4 (each within the scatter of the next). At a limit, above all of these: compound 1.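

The carbonyl carbon is a second position in the series that responds: in this assay, pyridin-4-yl in place of thiophen-2-yl brings a 6.7-fold higher number from compound 3 to compound 4 (0.82 log units; beyond the scatter), a modest step. With the rest of compound 3 held fixed, this six-membered aromatic ring therefore gives weaker inhibition than the five-membered one. Nothing measured here accounts for the step.

Open, on these data alone, is whether the ring size or the ring nitrogen tracks with the change; phenyl or furan-2-yl on the carbonyl carbon would separate the two. Pyridin-3-yl would show whether the place of the ring nitrogen matters.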